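This account rests on a few compounds, and the source may have more. Where it says the series, first, only, none or still open, it means among the compounds named here.

Notes on the series. In an assay on isolated protein for displacement of a labelled ligand from metabotropic glutamate receptor 5 (Homo sapiens), with a stated time of 60 min, tested at 1 uM (on this read-out lower numbers stand for less inhibition and higher numbers for more inhibition at the one concentration tested (going by the name of the read-out)), compound 1 `COc1ccc2ncc(S(=O)(=O)c3ccc(C)cc3)c(N3CCC(C)CC3)c2c1` gives 90%. Compound 3 `COc1ccc2ncc(S(=O)(=O)c3ccc(C)c(F)c3)c(N3CCC(C)CC3)c2c1` gives 73% in this assay, and compound 2 `CC1CCN(c2c(S(=O)(=O)c3ccc(F)c(F)c3)cnc3ccc(F)cc23)CC1` gives 82%. The step of a number 17 percentage points higher from compound 3 to compound 1 (beyond the scatter) corresponds to hydrogen in place of fluoro on an aromatic carbon. The difference between the core of compound 2 and the core of compound 3 is not broken down here; their values in this assay lie within the usual scatter of each other. Compound 4 `CC1CCN(c2c(S(=O)(=O)c3cccc(F)c3)cnc3ccc(F)cc23)CC1` is not yet measured; it differs from compound 2 by hydrogen in place of fluoro on an aromatic carbon, the same kind of change as from compound 3 to compound 1, though here the place is ortho to a fluoro group and para to a large group rather than ortho to a methyl group and meta to a large group. Compound 2 already stands at 82%, which leaves little room upward. Among the compounds with values here, the expected step here is a number 6 percentage points higher from compound 2 to compound 4 (within the scatter) because a number 17 percentage points higher from compound 3 to compound 1 (beyond the scatter) is the one measured instance of this kind of change. Compound 4 is thus estimated at 88%, between 76% and 97%.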

Compound 4, a percentage reported as inhibition, at one concentration (the size of the read-out at that concentration, not a potency): 76%
Beside the measured number, compound 4's estimate is 12 percentage points above it; measured number inside the range.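

In this assay, hydrogen in place of fluoro on an aromatic carbon gives a number 6 percentage points lower from compound 2 to compound 4 (within the scatter), so on the core of compound 2 this step does not stand out from the scatter. The change does not carry over as a fixed step from one core to the other: the same change on two cores in this assay, a number 17 percentage points higher (beyond the scatter) from compound 3 to compound 1 and a number 6 percentage points lower (within the scatter) from compound 2 to compound 4, 23 percentage points apart, beyond the scatter of two such steps This does not show what sets the two steps apart, as the two pairs differ in the core and also in the place of the change, and two pairs give no rule for the series.

The compounds shown leave open how a nitrile or a carboxylic acid would read on the aromatic ring carrying the change. They also leave open whether the two steps would keep their gap as potencies, since each number comes from one concentration.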